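A few compounds are considered here, and "the series" means these few. Any claim that something is new, unique, unknown or untested is made for them only; others in the source may bear on it.

Three compounds share one core and were run in an assay on a protein complex for positive allosteric modulation of Neuronal acetylcholine receptor; alpha4/beta2 (Homo sapiens); on this read-out higher numbers stand for larger maximal responses and lower numbers for smaller maximal responses. Compound 1 `Fc1cccc(Cl)c1-c1cc(-c2cnn(C3CCNCC3)c2)on1` gives 60%, compound 2 `Fc1cccc(-c2cc(-c3cnn(C4CCNCC4)c3)on2)c1Cl` gives 47%, and compound 3 `Clc1sccc1-c1cc(-c2cnn(C3CCNCC3)c2)on1` gives 42%. Compound 3 stands lowest of the three: the step of a number 5 percentage points lower from compound 2 to compound 3 (within the scatter) lies within the scatter, whereas a number 18 percentage points lower from compound 1 to compound 3 (beyond the scatter) and a number 13 percentage points lower from compound 1 to compound 2 (beyond the scatter) lie beyond it. Compound 4 `c1nn(C2CCNCC2)cc1-c1cc(C2CCCCC2)no1` differs from compound 3 in one place: cyclohexyl in place of 2-chlorothiophen-3-yl on an aromatic carbon. Going by the values given here, no measured step exchanges this group for a non-aromatic ring, so the two steps ending at compound 3 only show that changes at this position have moved this assay modestly downward. For compound 4 a small further drop is expected, a number 7 percentage points lower from compound 3 to compound 4 (within the scatter), so compound 4 is estimated at 35%, within 15% to 55%.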

Compound 4, largest response reached (reported as efficacy), in percent of the reference or control that the assay uses: 16%
Estimate against measurement, compound 4: 19 percentage points above; measured number inside the range.
By their numbers in this assay, from the lowest: compound 4; then compounds 3 and 2 (each within the scatter of the next); then compound 1.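

In this assay, cyclohexyl on this aromatic carbon next to the ring nitrogen gives the first large losses at this position: a number 31 percentage points lower from compound 2 to compound 4 (beyond the scatter) and a number 44 percentage points lower from compound 1 to compound 4 (beyond the scatter), while a number 26 percentage points lower from compound 3 to compound 4 (beyond the scatter) is modest but still beyond the scatter. All three chlorine-bearing aromatic groups therefore stand above this carbon-only, non-aromatic ring. Nothing available explains the drop. Cyclohexyl removes both the aromatic ring and the chlorine, so the compounds shown cannot separate the two changes. On these data alone, whether an unsubstituted phenyl or a chlorocyclohexyl group would hold the response remains open.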